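The compounds below may be only part of what the source reports. "The series", "measured", "known", "first", "only" and "open" are said of these compounds alone.

Measured in a physicochemical assay for solubility, in phosphate buffer, at pH 6.8; on this read-out higher numbers stand for higher solubility and lower numbers for lower solubility:
- Compound 1 `CCn1c(NC(C)C)nc2c(C3CCNCC3)csc2c1=O`: 1100 ug/mL
- Compound 2 `CCn1c(NC(C)C)nc2c(-c3cccnc3)csc2c1=O`: 5.8 ug/mL
- Compound 3 `CCn1c(NC(C)C)nc2c(-c3ccnc(OC)c3)csc2c1=O`: 2.4 ug/mL

Of these three numbers in this assay, compound 3 stands lowest, at 2.4 ug/mL. Its nearest neighbour shows a 2.4-fold lower number from compound 2 to compound 3 (0.38 log units; beyond the scatter), a modest step. The furthest shows a 460-fold lower number from compound 1 to compound 3 (2.66 log units; beyond the scatter), a large step, and a 190-fold lower number from compound 1 to compound 2 (2.28 log units; beyond the scatter) is large as well.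

The next analogue is compound 4 `CCn1c(NC(C)C)nc2c(-c3ccco3)csc2c1=O`, in which furan-2-yl stands in place of 2-methoxypyridin-4-yl on an aromatic carbon: furan-2-yl in place of 2-methoxypyridin-4-yl on an aromatic carbon. Both large steps take away piperidin-4-yl, and nothing of that kind happens here, so they offer little guidance. Going by the values given here, the closer precedent is a 2.4-fold lower number from compound 2 to compound 3 (0.38 log units; beyond the scatter), the only measured exchange of one aromatic ring for another. Among the compounds with values here, no compound carrying furan-2-yl has been measured, so the direction remains open, and only a small change is expected, with a wide margin on either side. The expected change is a 1.3-fold higher number from compound 3 to compound 4 (0.10 log units; within the scatter). This expectation rests on compound 3 at 2.4 ug/mL and on the modest size of a 2.4-fold lower number from compound 2 to compound 3 (0.38 log units; beyond the scatter). In this assay the estimate for compound 4 is 3 ug/mL, with the measurement expected to fall between 1 ug/mL and 10 ug/mL.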

Compound 4, solubility: 0.1 ug/mL
Beside the measured number, compound 4's estimate is 30-fold (1.48 log units) above it, and the stated range ends above it.
By their numbers in this assay, from the lowest: compound 4; then compound 3; then compound 2; then compound 1.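

At this position, on an aromatic carbon two ring bonds from the ring sulfur, the choice of aromatic ring matters far more in this assay than the earlier exchange of pyridin-3-yl for 2-methoxypyridin-4-yl, with a 2.4-fold lower number from compound 2 to compound 3 (0.38 log units; beyond the scatter), could show. Furan-2-yl gives a 24-fold lower number from compound 3 to compound 4 (1.38 log units; beyond the scatter) when it replaces 2-methoxypyridin-4-yl and a 58-fold lower number from compound 2 to compound 4 (1.76 log units; beyond the scatter) when it replaces pyridin-3-yl, so both six-membered aromatic rings stand well clear of this one five-membered aromatic ring, though a single compound cannot establish a rule for ring size. Going by these compounds alone, with an 11000-fold lower number from compound 1 to compound 4 (4.04 log units; beyond the scatter) for furan-2-yl in place of piperidin-4-yl, the range reachable through this one position on the shared core is also much wider than the earlier compounds showed.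

The compounds shown leave open whether another five-membered aromatic ring, such as thiazole or pyrazole, would follow compound 4 or the pyridines, and whether a furan carrying an aminomethyl group, or a morpholine in this place, would move the number back towards that of compound 1. Nothing measured here bears on why furan-2-yl gives so low a number.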